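Swapping the pyridine for a pyrimidine on the biaryl core

This account rests on a few compounds, and the source may have more. Where it says the series, first, only, none or still open, it means among the compounds named here.

Compound 1, with the structure `c1cncc(-c2ccccc2OCC2=NCCN2)c1`, is the reference point of this small set. Among the compounds with values here, in a functional assay for activation of Alpha-1D adrenergic receptor (Homo sapiens), read by calcium flux (a higher number here means that more compound is needed for the effect, a lower number that less compound is needed), compound 1 gives 158 nM, and this is the only full number in the set. The companion compound 2, with the structure `Cc1ccnc(-c2ccccc2OCC2=NCCN2)c1`, is recorded in this assay only as a limit of the assay, < 100000 nM, rather than as a number. Within the data shown here, that limit is described by the limit of < 100000 nM in this assay, at which 1 of the 2 values shown sits, so compound 1 stands as the one compound with a measured potency.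

The unmeasured compound 3, with the structure `c1ccc(-c2ccncn2)c(OCC2=NCCN2)c1`, differs from compound 1 in one place: pyrimidin-4-yl in place of pyridin-3-yl on an aromatic carbon. Among the measured compounds shown here, no measured pair in the set shows the effect of this particular change, so the expectation rests only on compound 1 and on the fact that the one other aryl variant, compound 2, reached no number. A weakening step from compound 1 to compound 3 of a 7.6-fold higher number from compound 1 to compound 3 (0.88 log units; beyond the scatter) is expected in this assay, clearly beyond the usual scatter. Compound 3 is therefore estimated at 1200 nM, with a plausible range from 250 nM to 8000 nM.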

Compound 3, half-maximal effective concentration: < 100000 nM
Compound 3: a limit, no number; the forecaster's own chance of this, stated with the estimate: 15%; the middle value lies beyond the limit too.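

Compound 3 is recorded in this assay as a limit of the assay and not as a number, so the size of the change on going from compound 1 to compound 3 cannot be read: the limit of < 100000 nM in this assay, at which 2 of the 3 values shown sit.

The compounds shown leave open how much pyrimidin-4-yl in place of pyridin-3-yl changes the number, and whether any other variant of compound 1 would give a full number.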